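The source may hold more compounds than are shown below. What is called first, only, known or untested is meant among the compounds shown, and "the series" means these compounds.

Measured compounds:
Compound 1 `O=[N+]([O-])c1cccc(C2=NC(c3ccc(F)cc3)(c3ccc(F)cc3)CN2)c1`: in an assay on LM cells for displacement of a labelled ligand from Neuropeptide Y receptor type 5 (Homo sapiens) (a lower number here means a stronger inhibitor, a higher number a weaker inhibitor), compound 1 gives 4.3 nM.
Compound 2 `CC(=O)c1cccc(C2=NC(c3ccc(F)cc3)(c3ccc(F)cc3)CN2)c1`: compound 2 gives 44 nM.
Compound 3 `Fc1ccc(C2(c3ccc(F)cc3)CNC(c3cccs3)=N2)cc1`: compound 3 gives 54 nM.

Compound 3 carries the highest of the three numbers. Compound 2 stands close to it, as a 1.2-fold higher number from compound 2 to compound 3 (0.09 log units; within the scatter) shows, a gap within the scatter, so no order between these two can be read. Compound 1 is the furthest away, with a 13-fold higher number from compound 1 to compound 3 (1.10 log units; beyond the scatter).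

Compound 4 `Fc1ccc(C2(c3ccc(F)cc3)CNC(c3cncnc3)=N2)cc1` differs from compound 3 in one place: pyrimidin-5-yl in place of thiophen-2-yl on a carbon with a double bond to nitrogen. The measured steps that bear on this change are the two that also exchange the aryl group on this carbon: a 13-fold higher number from compound 1 to compound 3 (1.10 log units; beyond the scatter), a large step, and a 1.2-fold higher number from compound 2 to compound 3 (0.09 log units; within the scatter), which stays within the scatter. These two disagree in size, and neither involves pyrimidin-5-yl, so the step to compound 4 cannot be read off directly. On balance only a small step is expected: a 1.5-fold higher number from compound 3 to compound 4 (0.17 log units; within the scatter). The estimate for compound 4 in this assay is 80 nM, with a range from 25 nM to 250 nM.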

Compound 4, half-maximal inhibitory concentration: 47 nM
Compound 4: the middle estimate sits 1.7-fold (0.23 log units) above what was measured; the measured number falls inside the stated range.
By their numbers in this assay, from the lowest: compound 1; then compounds 2, 4 and 3 (each within the scatter of the next).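

In this assay, a six-membered aromatic ring with 2 hetero atoms, pyrimidin-5-yl, takes the place of the five-membered thiophen-2-yl with no readable change (a 1.1-fold lower number from compound 3 to compound 4 (0.06 log units; within the scatter)), and it also cannot be told apart from the 3-acetylphenyl group (a 1.1-fold higher number from compound 2 to compound 4 (0.03 log units; within the scatter)). On this carbon with a double bond to nitrogen, a change in ring size, in the hetero atoms and in the count of hydrogen-bond acceptors therefore leaves three different groups within the scatter of one another, with compound 1 alone beyond it (an 11-fold higher number from compound 1 to compound 4 (1.04 log units; beyond the scatter)). Nothing measured here accounts for the gap that sets the 3-nitrophenyl group apart from the other three.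

The compounds shown leave open whether that gap belongs to the nitro group itself or to a substituted phenyl ring more generally, which a plain phenyl, a 3-cyanophenyl or a 3-aminophenyl group on the same carbon would help to separate. They also leave open whether pyridin-3-yl, with a single ring nitrogen, would stay with pyrimidin-5-yl and thiophen-2-yl or move towards compound 1.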